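Rearranging the alkynyl ester of compound 2

The source may hold more compounds than are shown below. What is called first, only, known or untested is meant among the compounds shown, and "the series" means these compounds.

Measured compounds and their values:
compound 1, `CCn1c(C(=O)NCCCN(C)C)ccc1C(CC)(CC)c1ccc(OCCC(O)(CC)CC)c(C)c1`, 5 nM
compound 2, `C#CC(C)OC(=O)c1ccc(C(CC)(CC)c2ccc(OCCC(O)(CC)CC)c(C)c2)n1CC`, 2650 nM

Among the compounds with values here, in an assay on cells for agonist activity at vitamin D3 receptor (Homo sapiens), with a stated time of 96 h (on this read-out higher numbers stand for an effect only at larger amounts of compound and lower numbers for an effect already at smaller amounts), compound 2 stands at the highest of the two numbers measured so far; its nearest neighbour is compound 1, reached by a 530-fold higher number from compound 1 to compound 2 (2.72 log units; beyond the scatter). Compound 3, `C#CCCOC(=O)c1ccc(C(CC)(CC)c2ccc(OCCC(O)(CC)CC)c(C)c2)n1CC`, has the same atoms as compound 2 joined differently: but-3-yn-1-yl in place of 1-methylprop-2-yn-1-yl on an oxygen next to a carbonyl group. Within the data shown here, the only measured step, from compound 1 to compound 2, swaps an amine-bearing amide for an ester, so it does not compare two esters of this kind and bears on the present change only indirectly. Among the measured compounds shown here, with no step of the same kind on record, the expectation for compound 3 is a 1.1-fold lower number from compound 2 to compound 3 (0.03 log units; within the scatter), that is, no change beyond the scatter in this assay . Compound 3 is therefore estimated at 2500 nM, with a range from 700 nM to 9000 nM.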

Compound 3, half-maximal effective concentration: 6030 nM
Compound 3: middle estimate off by 2.4-fold (0.38 log units), on the low side, within the range that was stated.
By their numbers in this assay, from the lowest: compound 1; then compound 2; then compound 3.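

In this assay, the arrangement of the alkynyl chain on an oxygen next to a carbonyl group does register: but-3-yn-1-yl in place of 1-methylprop-2-yn-1-yl gives a 2.3-fold higher number from compound 2 to compound 3 (0.36 log units; beyond the scatter), a modest step but one beyond the scatter. This step is small beside a 1200-fold higher number from compound 1 to compound 3 (3.08 log units; beyond the scatter), which comes with (but-3-yn-1-yl)oxy in place of (3-(dimethylamino)propyl)amino on a carbonyl carbon, so this second ester also sits far above the amide compound 1. Nothing at hand explains the difference between the two alkynyl chains.

Still open, from the compounds shown here alone, is whether an ester carrying the amine of compound 1, a 3-(dimethylamino)propyl group on the oxygen, would bring the number down. Also open, going by these compounds, is how a carboxylic acid or a longer alkynyl chain would read in this assay.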